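From 4-(trifluoromethyl)phenyl to 1-phenylethyl at the limit

This account rests on a few compounds, and the source may have more. Where it says the series, first, only, none or still open, it means among the compounds named here.

Compound 1 (`O=C(Nc1ccc(Br)cc1)Nc1ccc(Nc2ncnc3[nH]ncc23)cc1`), compound 2 (`Cc1cccc(NC(=O)Nc2ccc(Nc3ncnc4[nH]ncc34)cc2)c1C`) and compound 3 (`O=C(Nc1ccc(Nc2ncnc3[nH]ncc23)cc1)Nc1ccc(C(F)(F)F)cc1`) share a core and differ in the group on an amide-type nitrogen. In a functional assay on HeLa cells (Homo sapiens) for inhibition, read by MTT assay, with a stated time of 72 h (on this read-out higher numbers stand for weaker inhibition and lower numbers for stronger inhibition), compound 1 gives > 10000 nM, which is a limit and not a number. Compound 2 gives > 10000 nM, again a limit. Compound 3 gives > 10000 nM, also a limit, so it has no numerical standing of its own. All three compounds therefore stand at the limit of > 10000 nM in this assay, at which 3 of the 3 values shown sit.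

Starting from compound 3, compound 4 (`CC(NC(=O)Nc1ccc(Nc2ncnc3[nH]ncc23)cc1)c1ccccc1`) has 1-phenylethyl in place of 4-(trifluoromethyl)phenyl on an amide-type nitrogen. Going by the values given here, three measured steps bear on this change: a step that the two limits leave unreadable from compound 1 to compound 2, a step that the two limits leave unreadable from compound 1 to compound 3 and a step that the two limits leave unreadable from compound 2 to compound 3. None of them has a readable size, so they indicate no direction. The closest is a step that the two limits leave unreadable from compound 2 to compound 3, which also exchanges the whole group on that nitrogen. Given (the limit of > 10000 nM in this assay, at which 3 of the 3 values shown sit), no step beyond the scatter is expected in this assay, although these limits constrain the expectation only loosely. The estimated change is a step that the limit leaves unreadable from compound 3 to compound 4. For compound 4 the expected value is 15000 nM, with an estimated range from 4000 nM to 50000 nM.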

Compound 4, half-maximal inhibitory concentration: > 10000 nM
Compound 4 ended at the assay's limit; the forecaster's own chance of this, stated with the estimate: 80%; the middle value lies beyond the limit too.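

In this assay compound 4 gives > 10000 nM, which is a limit and not a number, so its steps from compound 1, compound 2 and compound 3 cannot be read. All four compounds now stand together: the limit of > 10000 nM in this assay, at which 4 of the 4 values shown sit. The compounds shown leave open how far apart they lie, and whether any group on that amide-type nitrogen gives a readable value in this assay.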